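This account rests on a few compounds, and the source may have more. Where it says the series, first, only, none or still open, it means among the compounds named here.

In a functional assay on HT-29 cells (Homo sapiens) for antiproliferative activity, read by sulforhodamine B assay, with a stated time of 48 h (on this read-out higher numbers stand for weaker inhibition and lower numbers for stronger inhibition), two compounds sharing one core have been measured so far. Compound 1 `CCN1CCN(c2ccc(S(=O)(=O)Oc3cccc(OC)c3)cc2)C1=O`, which carries a methoxy group, gives 22000 nM, and compound 2 `CCN1CCN(c2ccc(S(=O)(=O)Oc3cccc(Cl)c3)cc2)C1=O`, which has chloro in its place, gives 6800 nM. Compound 2 therefore holds the lower of the two numbers, meaning the stronger inhibition in this assay. Compound 3 `CCN1CCN(c2ccc(S(=O)(=O)Oc3cccc(I)c3)cc2)C1=O` carries iodo in place of chloro on an aromatic carbon, meta to a large group (iodo in place of chloro on an aromatic carbon). Among the measured compounds shown here, only one measured step bears on this change: a 3.2-fold lower number from compound 1 to compound 2 (0.51 log units; beyond the scatter). For the measured compounds named here, that step exchanged a different pair of groups, and no measured compound carries iodo, so it offers only loose guidance. The estimated step is a 1.5-fold lower number from compound 2 to compound 3 (0.18 log units; within the scatter), a small further fall in the number that may stay within the scatter. For compound 3 the estimated value is 4500 nM, with an expected range from 1800 nM to 11000 nM.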

Compound 3, half-maximal inhibitory concentration: 3100 nM
Compound 3: middle estimate off by 1.5-fold (0.16 log units), on the high side; the measured number falls inside the stated range.
By their numbers in this assay, from the lowest: compound 3; then compound 2; then compound 1.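

In this assay this place on the aromatic carbon, meta to a large group, now gives a second step beyond the scatter, a 2.2-fold lower number from compound 2 to compound 3 (0.34 log units; beyond the scatter), so exchanging one halogen for another moves the number, which the step from methoxy to chloro could not show. Set against methoxy, iodo gives a 7.1-fold lower number from compound 1 to compound 3 (0.85 log units; beyond the scatter), and the three groups now run methoxy, chloro, iodo from the highest number to the lowest, with no compound shown going against that order. Nothing available explains this order.

The compounds shown leave open where bromo, an amine or a carboxylic acid would fall at this place. They also leave open whether the same order would hold with a longer chain in place of the ethyl group on the shared core.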